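A few compounds are considered here, and "the series" means these few. Any claim that something is new, unique, unknown or untested is made for them only; others in the source may bear on it.

Within the data shown here, in a functional assay on KB cells (Homo sapiens) for cytotoxicity (on this read-out higher numbers stand for weaker inhibition and lower numbers for stronger inhibition), compound 1 `COc1ccc(S(=O)(=O)N2CCc3cccc(NC(=O)c4ccc(F)cc4)c32)cc1` gives 85 nM and compound 2 `COc1ccc(S(=O)(=O)N2CCc3cccc(NC(=O)c4ccncc4)c32)cc1` gives 8.9 nM, the lower of the two numbers so far. Among the measured compounds shown here, only one measured step bears on this position: a 9.6-fold lower number from compound 1 to compound 2 (0.98 log units; beyond the scatter), with pyridin-4-yl in place of 4-fluorophenyl on a carbonyl carbon. That step lies beyond the usual scatter, so the group held on this carbonyl carbon is shown to matter in this assay. Compound 3 `COc1ccc(S(=O)(=O)N2CCc3cccc(NC(=O)c4ccco4)c32)cc1` has not yet been measured. It carries furan-2-yl in place of pyridin-4-yl on a carbonyl carbon. For the measured compounds named here, no measured compound carries furan-2-yl, so the direction of the change rests on thin evidence. Going by the values given here, a rise is still the more likely outcome, since compound 2 at 8.9 nM holds the lower number, and the rise is expected to be smaller than the one measured step. The expected change is a 2.5-fold higher number from compound 2 to compound 3 (0.39 log units; beyond the scatter). For compound 3 the estimated value is 22 nM, with an expected range from 7 nM to 80 nM.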

Compound 3, half-maximal inhibitory concentration: 9.2 nM
Estimate against measurement, compound 3: 2.4-fold (0.38 log units) above; the measured number falls inside the stated range.
By their numbers in this assay, from the lowest: compounds 2 and 3 (each within the scatter of the next); then compound 1.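

In this assay the exchange of pyridin-4-yl for furan-2-yl on the carbonyl carbon gives a 1.0-fold higher number from compound 2 to compound 3 (0.01 log units; within the scatter) and so leaves the read-out unchanged, although a six-membered aromatic ring with a nitrogen gives way to a smaller five-membered one with an oxygen. Set against the 4-fluorophenyl group, furan-2-yl gives a 9.2-fold lower number from compound 1 to compound 3 (0.97 log units; beyond the scatter) in a step much the same in size as a 9.6-fold lower number from compound 1 to compound 2 (0.98 log units; beyond the scatter) and this shows that the separation from compound 1 is not tied to pyridin-4-yl alone, since two different rings, each with one hetero atom, now share it. Nothing measured here accounts for why these groups fall as they do.

From the compounds shown here alone, what remains open is whether the fluorine or the all-carbon ring sets compound 1 apart, a question that an unsubstituted phenyl group on the same carbonyl carbon would address. Equally unsettled is how far the tolerance at this position extends, for example to thiophen-2-yl, to pyridin-3-yl or to a saturated ring amine such as piperidin-4-yl.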